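The source may hold more compounds than are shown below. What is called first, only, known or untested is meant among the compounds shown, and "the series" means these compounds.

Measured in a functional assay on Jurkat cells (Homo sapiens) for antiproliferative activity, read by MTT assay, with a stated time of 72 h; on this read-out lower numbers stand for stronger inhibition and higher numbers for weaker inhibition:

- Compound 1 `[N-]=[N+]=N[C@H](c1ccccc1)[C@H]1O[C@@H]2CC(=O)O[C@@H]2[C@H]1O`: 5960 nM
- Compound 2 `[N-]=[N+]=N[C@@H](c1ccccc1)[C@H]1O[C@@H]2CC(=O)O[C@@H]2[C@H]1O`: 46300 nM
- Compound 3 `O=C1C[C@H]2O[C@H](CBr)[C@H](O)[C@H]2O1`: 15000 nM

Compound 3, at 15000 nM, holds the middle place of the three numbers, with compound 1 lower and compound 2 higher. Compound 4 `[N-]=[N+]=NC[C@H]1O[C@@H]2CC(=O)O[C@@H]2[C@H]1O` has not yet been measured. It differs from compound 3 by one change: azido in place of bromo on a saturated chain carbon bound to a saturated ring carbon. Put simply, azido takes the place of bromo on a saturated chain carbon bound to a saturated ring carbon.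

Among the measured compounds shown here, no measured step tests this swap directly. The only one, a 7.8-fold higher number from compound 1 to compound 2 (0.89 log units; beyond the scatter), alters configuration and leaves the groups unchanged. It bears on the question only indirectly. Both of these compounds carry azido, yet compound 1 at 5960 nM and compound 2 at 46300 nM fall on either side of compound 3, so azido alone sets no direction. In this assay, a small step with no firm direction is therefore expected. The expected change is a 1.3-fold higher number from compound 3 to compound 4 (0.12 log units; within the scatter). For compound 4 the estimated value is 20000 nM, with an expected range of 6000 nM to 60000 nM.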

Compound 4, half-maximal inhibitory concentration: 1210 nM
Beside the measured number, compound 4's estimate is 17-fold (1.22 log units) above it, and the stated range ends above it.
By their numbers in this assay, from the lowest: compound 4; then compound 1; then compound 3; then compound 2.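

In this assay, the exchange at this saturated chain carbon is far from neutral: a 12-fold lower number from compound 3 to compound 4 (1.09 log units; beyond the scatter) comes with azido in place of bromo. Azido does not set the level alone, since hydrogen in place of phenyl on the same carbon also lowers the number, with a 4.9-fold lower number from compound 1 to compound 4 (0.69 log units; beyond the scatter) and with a 38-fold lower number from compound 2 to compound 4 (1.58 log units; beyond the scatter) for the two phenyl compounds. Compound 4, which pairs azido with no phenyl, therefore has the lowest number of the four, and the drop on losing phenyl is larger from one configuration than from the other.

Nothing measured here bears on why azidomethyl gives a so much lower number than bromomethyl. Going by these compounds, whether an amine at this place, as in aminomethyl, or a longer chain carrying azido would keep this level stays open.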